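The source may hold more compounds than are shown below. What is called first, only, known or untested is meant among the compounds shown, and "the series" means these compounds.

In a functional assay on HaCaT cells (Homo sapiens) for inhibition, read by sulforhodamine B assay, with a stated time of 48 h (a lower number here means a stronger inhibitor of growth, a higher number a weaker inhibitor of growth), three compounds sharing one core have been measured. Compound 1 (`CC1(/C=C/c2ccccc2C(F)(F)F)C=CC(=O)O1`) gives 12700 nM, compound 2 (`COc1ccc(/C=C/C2(C)C=CC(=O)O2)c(OC)c1`) gives 53600 nM, and compound 3 (`COc1cc(OC)c(/C=C/C2(C)C=CC(=O)O2)c(OC)c1`) gives 458000 nM. The value for compound 2 is thus the second highest of the three numbers. Compound 4 (`COc1ccccc1/C=C/C1(C)C=CC(=O)O1`) has not yet been measured. It differs from compound 2 by hydrogen in place of methoxy on an aromatic carbon. Going by the values given here, one measured step bears on this change, and it is the same kind of swap run the other way. Methoxy in place of hydrogen on an aromatic carbon gave an 8.5-fold higher number from compound 2 to compound 3 (0.93 log units; beyond the scatter), a modest step beyond the scatter, toward a weaker inhibitor of growth. A single step is thin evidence and cannot simply be reversed in full, so a smaller step toward a lower number is expected in this assay. The expected change is a 2.1-fold lower number from compound 2 to compound 4 (0.33 log units; beyond the scatter). The estimate for compound 4 is 25000 nM, within an expected range of 8000 nM to 80000 nM.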

Compound 4, concentration for total growth inhibition: 30800 nM
Compound 4: the middle estimate sits 1.2-fold (0.09 log units) below what was measured; measured number inside the range.
By their numbers in this assay, from the lowest: compound 1; then compounds 4 and 2 (each within the scatter of the next); then compound 3.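

Removing the methoxy para to a group of 9 heavy atoms gives a 1.7-fold lower number from compound 2 to compound 4 (0.24 log units; within the scatter) in this assay, so this position shows no clear effect of the group. Methoxy groups therefore do not all count alike here, as the one added in going to compound 3 gave an 8.5-fold higher number from compound 2 to compound 3 (0.93 log units; beyond the scatter) in the same test. Trifluoromethyl and methoxy do separate at an aromatic carbon, with a 2.4-fold higher number from compound 1 to compound 4 (0.38 log units; beyond the scatter) for that swap, so the group kept on the ring still matters. Nothing available here explains these differences.

Still open, as far as these compounds go, is whether a hydroxyl group, an amine or a chlorine in place of the removed methoxy would shift the number. The same question stands for a ring carrying only hydrogen, with neither methoxy nor trifluoromethyl.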